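The source may report more compounds than this note shows. Statements on the series, on what has been measured and on what is new or still open speak of the compounds shown alone.

Compound 1 `COc1ccc(-c2[nH]c3cc(OC)cc(OC)c3c(=O)c2I)cc1` gives only the limit > 86200 nM in a functional assay on SUP-B15 cells (Homo sapiens) for antiproliferative activity, with a stated time of 72 h; on this read-out higher numbers stand for an effect only at larger amounts of compound and lower numbers for an effect already at smaller amounts. Compound 2 `COc1ccc(-c2cc(=O)c3c(OC)cc(OC)cc3n2S(=O)(=O)c2ccc([N+](=O)[O-])cc2)cc1` gives 17100 nM in this assay.

Among the measured compounds shown here, compound 2 thus holds the only measured number, the other value being a limit (the limit of > 86200 nM in this assay, at which 1 of the 2 values shown sits). Compound 3 `COc1ccc(-c2cc(=O)c3c(OC)cc(OC)cc3n2S(=O)(=O)c2cc(F)c(F)c(F)c2)cc1` differs from compound 2 in one place: 3,4,5-trifluorophenyl in place of 4-nitrophenyl on a sulfonyl sulfur. For the measured compounds named here, no step between measured compounds exists to guide the size of this change, so the shift in this assay is expected to be small, within the usual scatter or little beyond it, as a 1.2-fold higher number from compound 2 to compound 3 (0.07 log units; within the scatter). Compound 3 is estimated at 20000 nM, between 6000 nM and 65000 nM.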

Compound 3, half-maximal effective concentration: > 65500 nM
Compound 3 was reported as a limit (the forecaster's own chance of this, stated with the estimate: 25%); at least 3.2-fold (0.51 log units) between middle value and limit.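

On a sulfonyl sulfur whose other neighbour is an aromatic nitrogen, the choice of aryl group proves to matter in this assay: 3,4,5-trifluorophenyl in place of 4-nitrophenyl gives an at least 3.8-fold higher number from compound 2 to compound 3 (0.58 log units; beyond the scatter). As far as these compounds go, the true size of this step stays unknown, since compound 3 reaches only a limit. Compound 2 therefore keeps the only measured number, while the other compounds rest at limits: the limit of > 65500 nM in this assay, at which 1 of the 3 values shown sits.

What the compounds shown leave open is why 4-nitrophenyl reads better than 3,4,5-trifluorophenyl. Also open, from the compounds shown here alone, is how an amine or a carboxylic acid on that ring, or a simple methyl on the sulfonyl sulfur, would behave in this assay.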